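The source may hold more compounds than are shown below. What is called first, only, known or untested is meant among the compounds shown, and "the series" means these compounds.

Compound 3, `Cn1c(-c2ccccc2C(F)(F)F)nnc1C12CCC(CCCC(C)(F)F)(CC1)CC2`, is one of three compounds that share a core and differ only in the chain hanging from it. In an assay on CHO-K1 cells for inhibition of 11-beta-hydroxysteroid dehydrogenase type 2 (Mus musculus), read by scintillation proximity assay (a lower number here means a stronger inhibitor, a higher number a weaker inhibitor), compound 3 gives > 4000 nM, which is a limit of the assay rather than a number. Compound 1, `CCSCCC12CCC(c3nnc(-c4ccccc4C(F)(F)F)n3C)(CC1)CC2`, gives > 4000 nM in this assay, again a limit. Compound 2, `Cn1c(-c2ccccc2C(F)(F)F)nnc1C12CCC(CCS(C)(=O)=O)(CC1)CC2`, gives > 4000 nM in this assay, also a limit. The only evidence on the measured steps is the limit of > 4000 nM in this assay, at which 3 of the 3 values shown sit, so the steps among these compounds, a step that the two limits leave unreadable from compound 1 to compound 2, a step that the two limits leave unreadable from compound 1 to compound 3 and a step that the two limits leave unreadable from compound 2 to compound 3, cannot be read. Compound 4, `CC(O)CCCC12CCC(c3nnc(-c4ccccc4C(F)(F)F)n3C)(CC1)CC2`, is not yet measured. It differs from compound 3 by 1-hydroxyethyl in place of 1,1-difluoroethyl on a saturated chain carbon, three bonds along the chain from a saturated ring carbon; cut one bond further out, the same change reads 2,2-difluoropropyl to 2-hydroxypropyl. Going by the values given here, no measured step bears on this change, and the three values shown give no foothold beyond the limit. The expectation is therefore that compound 4 in this assay stays near the limit, with an expected step that the limit leaves unreadable from compound 3 to compound 4. Compound 4 is estimated at 6000 nM, in a range from 2000 nM to 20000 nM.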

Compound 4, half-maximal inhibitory concentration: > 4000 nM
Compound 4: only a limit was reported; the forecaster's own chance of this, stated with the estimate: 75%; the middle value does not contradict the limit.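

In this assay compound 4 gives > 4000 nM, which is a limit. The steps from compound 4 to compound 1, compound 2 and compound 3 therefore cannot be read: the limit of > 4000 nM in this assay, at which 4 of the 4 values shown sit. The compounds shown leave open whether any chain on the shared core gives an actual number in this assay.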